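Adding One Methoxy to Compound 2

This account rests on a few compounds, and the source may have more. Where it says the series, first, only, none or still open, it means among the compounds named here.

In an ADME assay on cells (Lymphocyte, Homo sapiens) for cytotoxicity, read by MTT assay, with a stated time of 48 h (a lower number here means a stronger inhibitor, a higher number a weaker inhibitor), compound 1 `COC(=O)/C(=C\c1ccc(O)cc1)Sc1ccnc2cc(Cl)ccc12` gives 33700 nM and compound 2 `COC(=O)/C(=C\c1ccc(OC(=O)c2cc(OC)cc(OC)c2)cc1)Sc1ccnc2cc(Cl)ccc12` gives 84100 nM, the higher of the two actual numbers. Compound 3 `COC(=O)/C(=C\c1ccc(OC(=O)c2cc(OCc3ccccc3)c(OCc3ccccc3)c(OCc3ccccc3)c2)cc1)Sc1ccnc2cc(Cl)ccc12` reads > 100000 nM, which is a limit of the assay and not a number. Compound 4 `COC(=O)/C(=C\c1ccc(OC(=O)c2cc(OC)cc(OC)c2OC)cc1)Sc1ccnc2cc(Cl)ccc12` differs from compound 2 in one place: methoxy in place of hydrogen on an aromatic carbon. In short, a methoxy takes the place of a hydrogen on an aromatic carbon. Among the measured compounds shown here, the one measured step that bears on this, a 2.5-fold higher number from compound 1 to compound 2 (0.40 log units; beyond the scatter), added a whole (3,5-dimethoxyphenyl)carbonyl group and was modest. A small rise or none beyond the scatter is therefore expected in this assay, and the expected change is a 1.1-fold higher number from compound 2 to compound 4 (0.05 log units; within the scatter). Compound 4 is estimated at 95000 nM, with an expected range from 50000 nM to 170000 nM.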

Compound 4, half-maximal inhibitory concentration: 74000 nM
Compound 4: the middle estimate sits 1.3-fold (0.11 log units) above what was measured; measured number inside the range.
By their numbers in this assay, from the lowest: compound 1; then compounds 4 and 2 (each within the scatter of the next). At a limit, above all of these: compound 3.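

In this assay, the step from 3,5-dimethoxyphenyl to 2,3,5-trimethoxyphenyl gives a 1.1-fold lower number from compound 2 to compound 4 (0.06 log units; within the scatter), so this methoxy leaves the reading unchanged within the scatter. Unlike the earlier step, which added a whole carbonyl-linked ring, this one alters a single position on that ring and shows that this aromatic carbon accepts a methoxy without a readable shift in this assay. Compound 3 stands at a limit, not a number: the limit of > 100000 nM in this assay, at which 1 of the 4 values shown sits.

From the compounds shown here alone, whether an amine or a carboxylic acid on this same carbon would shift the reading remains open.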